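From trifluoromethyl to methylsulfanyl on an aromatic carbon

A few compounds are considered here, and "the series" means these few. Any claim that something is new, unique, unknown or untested is made for them only; others in the source may bear on it.

Measured in a functional assay on HepG2 cells (Homo sapiens) for antiproliferative activity, read by MTT assay, with a stated time of 24 h; a higher number here means a weaker inhibitor, a lower number a stronger inhibitor:
Compound 1 `C=CCc1cc(-c2cccc(C(F)(F)F)c2)ccc1O`: 58300 nM
Compound 2 `C=CCOc1ccc(-c2ccc(OC)cc2)cc1CC=C`: > 100000 nM
Compound 3 `C=CCc1cc(-c2ccc(C(F)(F)F)cc2)ccc1OC`: 89000 nM

Compound 1, at 58300 nM, and compound 3, at 89000 nM, lie within the scatter of each other. Compound 2 gives > 100000 nM, which is a limit and not a number. Compound 4 `C=CCc1cc(-c2cccc(SC)c2)ccc1O` carries methylsulfanyl in place of trifluoromethyl on an aromatic carbon of compound 1 (methylsulfanyl in place of trifluoromethyl on an aromatic carbon). No measured step among these compounds covers such a change. In this assay, the expected outcome is a 1.0-fold higher number from compound 1 to compound 4 (0.01 log units; within the scatter), with no shift beyond the scatter in either direction. For compound 4, the estimated value is 60000 nM, with an expected range of 30000 nM to 100000 nM.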

Compound 4, half-maximal inhibitory concentration: > 100000 nM
Compound 4 was reported as a limit; the forecaster's own chance of this, stated with the estimate: 15%; at least 1.6-fold (0.22 log units) between middle value and limit.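

In this assay, methylsulfanyl in place of trifluoromethyl on an aromatic carbon gives an at least 1.7-fold higher number from compound 1 to compound 4 (0.23 log units; that floor lies within the scatter). From the compounds shown here alone, the result for compound 4 is a limit and not a number, so the true size of this step remains unknown and its floor does not establish a loss beyond the scatter. Compound 4 therefore adds no second measured number at this position, and the series gains another reading at the ceiling: the limit of > 100000 nM in this assay, at which 2 of the 4 values shown sit.

Going by these compounds, it remains open whether an amine or a carboxylic acid on the same aromatic carbon would give a value under that limit.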